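Aryl swap on the imidazolinone of compound 1

The source may hold more compounds than are shown below. What is called first, only, known or untested is meant among the compounds shown, and "the series" means these compounds.

Measured so far:
- compound 1 `C[C@H](c1ccc(C(=O)NCCC(=O)O)cc1)N1C(=O)C(c2cccc(OC(F)(F)F)c2)=N[C@]12CC[C@@H](C(C)(C)C)CC2`: 1500 nM
- compound 2 `CC1(CC[C@H](c2ccc(C(=O)NCc3nn[nH]n3)cc2)N2C(=O)C(c3cc(Cl)cc(Cl)c3)=N[C@]23CC[C@@H](C(C)(C)C)CC3)CC1`: 110 nM
- compound 3 `CCCCC[C@H](c1ccc(C(=O)NCc2nn[nH]n2)cc1)N1C(=O)C(c2cc(Cl)cc(Cl)c2)=N[C@]12CC[C@@H](C(C)(C)C)CC2`: 310 nM

All values come from an assay on membranes from liver for displacement of a labelled ligand from Glucagon receptor (Mus musculus), read by scintillation counting, with a stated time of 60 min; on this read-out higher numbers stand for weaker inhibition and lower numbers for stronger inhibition. Compound 1 gives the highest number of the three; compound 3 is the nearest, with 310 nM, and compound 2 the furthest, with 110 nM. Both of those carry a 3,5-dichlorophenyl, a tetrazolylmethyl amide and a larger substituent on the benzylic carbon, so none of them differs from compound 1 in a single place.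

Among the compounds with values here, the only single-place step among the measured compounds is a 2.8-fold higher number from compound 2 to compound 3 (0.45 log units; beyond the scatter), which concerns the saturated chain carbon and not the aryl group.

Compound 4 `C[C@H](c1ccc(C(=O)NCCC(=O)O)cc1)N1C(=O)C(c2cccc(Cl)c2F)=N[C@]12CC[C@@H](C(C)(C)C)CC2` differs from compound 1 as follows: 3-chloro-2-fluorophenyl in place of 3-(trifluoromethoxy)phenyl on a carbon with a double bond to nitrogen. Within the data shown here, no measured step in this assay touches that position, so there is no direct guide to the size or direction of the change. The lower numbers of compound 2 and compound 3 involve a halogenated phenyl at the same position, but with several other changes, so they give only weak support for a modest improvement.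

For compound 4 the expected value in this assay is 900 nM, within 250 nM to 3500 nM, an expected step of a 1.7-fold lower number from compound 1 to compound 4 (0.22 log units; within the scatter).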

Compound 4, half-maximal inhibitory concentration: 4000 nM
The estimate for compound 4 lay 4.4-fold (0.65 log units) below the measured number; measured number outside the range, above it.
By their numbers in this assay, from the lowest: compound 2; then compound 3; then compound 1; then compound 4.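

In this assay, within the data shown here, the aryl group on the carbon with a double bond to nitrogen gives the first single-place reading at this position: 3-chloro-2-fluorophenyl in place of 3-(trifluoromethoxy)phenyl gives a 2.7-fold higher number from compound 1 to compound 4 (0.43 log units; beyond the scatter) and is a modest step. On the core of compound 1 a halogenated phenyl therefore brings no gain by itself, and the lower numbers of compound 2 and compound 3, which carry several other changes, cannot be credited to halogens on the aryl ring alone. No measurement at hand accounts for the direction of this step.

As far as these compounds go, the swap changes more than one substituent at once, so it remains open which one carries the step; a 3-chlorophenyl and a 2-fluorophenyl on the same core would separate the two halogens from the loss of trifluoromethoxy. Also open, from the compounds shown here alone, is whether the order of these two aryl groups holds when the tetrazolylmethyl amide of compound 2 and compound 3 takes the place of the amide chain ending in a carboxylic acid.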